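The source may report more compounds than this note shows. Statements on the series, on what has been measured and on what is new or still open speak of the compounds shown alone.

Among the measured compounds shown here, in an ADME assay for permeability, using PAMPA, with a stated time of 4 h, at pH 7.4 (on this read-out higher numbers stand for higher permeability and lower numbers for lower permeability), only two compounds have numbers so far. Compound 1 (`NCCCCN(C[C@H]1Cc2ncccc2CN1)[C@H]1CCCc2cccnc21`) gives 14 nm/s, and compound 2 (`NCCCCN(C[C@@H]1Cc2ncccc2CN1)[C@H]1CCCc2cccnc21`) gives 7 nm/s. For the measured compounds named here, these two values lie within the scatter of each other, so compound 1 cannot be separated from its only neighbour on this scale.

The next structure is compound 3 (`NC(=O)NC/C=C\CN(C[C@H]1Cc2ncccc2CN1)[C@H]1CCCc2cccnc21`), and the change from compound 1 lies in a side chain: a group of 7 heavy atoms (4 carbon, 2 nitrogen, 1 oxygen; no ring) in place of a group of 4 heavy atoms (3 carbon, 1 nitrogen; no ring), on a saturated chain carbon bound to an amine nitrogen. In words, a longer group of 7 heavy atoms takes the place of the 3-aminopropyl group, on a saturated chain carbon bound to an amine nitrogen.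

Going by the values given here, the only measured step, a 2.0-fold lower number from compound 1 to compound 2 (0.30 log units; within the scatter), alters the configuration at one stereocentre and leaves the chain untouched. It therefore offers no size for a change of this kind, and the expectation has to start from compound 1 at 14 nm/s. With no measured guide to direction, a 1.2-fold lower number from compound 1 to compound 3 (0.07 log units; within the scatter) is the expected step, which means no expected shift beyond the scatter. Compound 3 is estimated at 12 nm/s, with an expected range from 4 nm/s to 40 nm/s.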

Compound 3, apparent permeability: 2 nm/s
Beside the measured number, compound 3's estimate is 6.0-fold (0.78 log units) above it, and the stated range ends above it.
By their numbers in this assay, from the lowest: compound 3; then compounds 2 and 1 (each within the scatter of the next).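

In this assay, the side chain on a saturated chain carbon bound to an amine nitrogen proves to be a place where the number can move: replacing the 3-aminopropyl group gives a 7.0-fold lower number from compound 1 to compound 3 (0.85 log units; beyond the scatter). Until now, the only step shown was a change of configuration that stayed within the scatter, so this is the first step here that clears the scatter and the first to touch the chain. Among the compounds shown here, nothing measured so far accounts for the size or direction of this step.

The entering group differs from 3-aminopropyl in several ways at once, including its heavy atoms, its double bonds outside aromatic rings and its hydrogen-bond donors, and this single step cannot tell these differences apart. The compounds shown leave open how a longer saturated chain ending in an amine, or a chain ending in a carboxylic acid, would read in this assay, and whether the stereocentre that separates compound 1 from compound 2 would count for more with the new group in place.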